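A few compounds are considered here, and "the series" means these few. Any claim that something is new, unique, unknown or untested is made for them only; others in the source may bear on it.

Compound 1 `CCCCCCCCCCCCCCNC(=O)[C@@H](NC(=O)c1cccs1)[C@@H](C)O` gives 78400 nM in a functional assay on SW-620 cells (Homo sapiens) for cytotoxicity, read by MTT assay, with a stated time of 48 h; on this read-out higher numbers stand for weaker inhibition and lower numbers for stronger inhibition.
Compound 2 `CCCCCCCCCCCCCCNC(=O)[C@@H](NC(=O)/C=C/c1ccccc1)[C@@H](C)O` gives 200000 nM in this assay.

Going by the values given here, compound 2 holds the highest of the two numbers in this assay; the only neighbour is compound 1, and the step of a 2.6-fold higher number from compound 1 to compound 2 (0.41 log units; beyond the scatter) lay beyond the scatter. Compound 3 `CCCCCCCCCCCCCCNC(=O)[C@@H](NS(=O)(=O)c1cccs1)[C@@H](C)O` carries (thiophen-2-yl)sulfonyl in place of (2-phenylethenyl)carbonyl on an amine nitrogen. Among the compounds with values here, no measured step changes a carbonyl to a sulfonyl on that nitrogen, so only the return toward a thiophen-2-yl group, seen through the step of a 2.6-fold higher number from compound 1 to compound 2 (0.41 log units; beyond the scatter), bears on it. Compound 3 is therefore expected to move by a 2.2-fold lower number from compound 2 to compound 3 (0.35 log units; beyond the scatter), toward compound 1. Compound 3 is estimated at 90000 nM, within 35000 nM to 250000 nM.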

Compound 3, half-maximal inhibitory concentration: 18400 nM
Compound 3: the middle estimate sits 4.9-fold (0.69 log units) above what was measured, outside the stated range (below it).
By their numbers in this assay, from the lowest: compound 3; then compound 1; then compound 2.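

In this assay the linking group on the amine nitrogen itself proves to matter: with the thiophen-2-yl group kept, (thiophen-2-yl)sulfonyl in place of (thiophen-2-yl)carbonyl gives a 4.3-fold lower number from compound 1 to compound 3 (0.63 log units; beyond the scatter) and places the sulfonyl compound lowest of the three. Replacing (2-phenylethenyl)carbonyl with (thiophen-2-yl)sulfonyl gives an 11-fold lower number from compound 2 to compound 3 (1.04 log units; beyond the scatter) and so spans the whole range of these compounds. Nothing available explains this shift. The compounds shown leave open whether a sulfonyl carrying a phenyl ring would give a similar number, and how a shorter chain would change it.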